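Notes: oxan-4-yl in place of pyrimidin-2-yl

A few compounds are considered here, and "the series" means these few. Any claim that something is new, unique, unknown or untested is made for them only; others in the source may bear on it.

In a physicochemical assay for solubility, read by LC-MS, in phosphate buffer, with a stated time of 24 h, at pH 6.8 (a higher number here means a more soluble compound, a lower number a less soluble compound), compound 3 (`C[C@H](NC(=O)c1ncccn1)c1ccc(NC(=O)N2CC(c3ccc(N)nc3)C2)cc1`) reads 300000 nM. Compound 1 (`C[C@H](NC(=O)C1CCOCC1)c1ccc(NC(=O)N2CC(c3cccnc3)C2)cc1`) reads 380000 nM, within the scatter of compound 3. Compound 2 (`C[C@H](NC(=O)c1cccc(F)c1)c1ccc(NC(=O)N2CC(c3ccc(N)nc3)C2)cc1`) reads 32000 nM, beyond the scatter of both others. Compound 3 therefore sits level with compound 1 and well clear of compound 2 on these three numbers.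

Compound 4 (`C[C@H](NC(=O)C1CCOCC1)c1ccc(NC(=O)N2CC(c3ccc(N)nc3)C2)cc1`) comes from compound 3 by a single change: oxan-4-yl in place of pyrimidin-2-yl on a carbonyl carbon.

Among the measured compounds shown here, the one measured step at this place is a 9.4-fold higher number from compound 2 to compound 3 (0.97 log units; beyond the scatter), a modest move with pyrimidin-2-yl in place of 3-fluorophenyl. It shows that the number can shift with the group on this carbonyl carbon, but it does not involve oxan-4-yl, so it gives no direct size for the new step. The closer guide is compound 1, which carries oxan-4-yl on a carbonyl carbon and reads 380000 nM, although its core differs from that of compound 4. On that basis, no step beyond the scatter is expected in this assay, and neither direction is favoured. The expected step is a 1.1-fold lower number from compound 3 to compound 4 (0.03 log units; within the scatter). The estimate for compound 4 is 280000 nM, with an expected range of 110000 nM to 600000 nM.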

Compound 4, solubility: 310000 nM
Estimate against measurement, compound 4: 1.1-fold (0.04 log units) below, within the range that was stated.
By their numbers in this assay, from the lowest: compound 2; then compounds 3, 4 and 1 (each within the scatter of the next).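

In this assay, oxan-4-yl in place of pyrimidin-2-yl on a carbonyl carbon gives a 1.0-fold higher number from compound 3 to compound 4 (0.01 log units; within the scatter) and so stays within the scatter, which means a non-aromatic ring with one hetero atom and an aromatic ring with two cannot be told apart here on the shared core. Against 3-fluorophenyl, oxan-4-yl gives a 9.7-fold higher number from compound 2 to compound 4 (0.99 log units; beyond the scatter) as well as the earlier 9.4-fold higher number from compound 2 to compound 3 (0.97 log units; beyond the scatter) for pyrimidin-2-yl, so among the three groups on this carbonyl carbon, compound 2 alone stands apart from the other two. The second place now has a reading too: amino in place of hydrogen on an aromatic carbon gives a 1.2-fold lower number from compound 1 to compound 4 (0.09 log units; within the scatter) and also stays within the scatter, with oxan-4-yl held fixed.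

From the compounds shown here alone, it remains open whether the low number of compound 2 belongs to the fluorine or to the carbocyclic ring, which unsubstituted phenyl on the same carbonyl carbon would separate, and how a carboxylic acid or a piperidin-4-yl amine would read at this place. No measurement at hand bears on what lies behind these numbers.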